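Trifluoromethyl in place of chloro on the fused ring

A few compounds are considered here, and "the series" means these few. Any claim that something is new, unique, unknown or untested is made for them only; others in the source may bear on it.

Among the measured compounds shown here, compound 2 `CN(O)C(=O)NCCSc1nc2cc(Cl)ccc2s1` stands lowest of the two numbers so far in a functional assay for inhibition of Polyunsaturated fatty acid 5-lipoxygenase (Homo sapiens); on this read-out lower numbers stand for an effect already at smaller amounts and higher numbers for an effect only at larger amounts of compound: compound 2 gives 20 nM, whereas compound 1 `CN(O)C(=O)NCCSc1nc2ccccc2s1` gives 90 nM. For the measured compounds named here, the single measured step, a 4.5-fold lower number from compound 1 to compound 2 (0.65 log units; beyond the scatter), is the only one that bears on the new change, and it concerns the same aromatic carbon. Compound 3 `CN(O)C(=O)NCCSc1nc2cc(C(F)(F)F)ccc2s1` differs from compound 2 by trifluoromethyl in place of chloro on an aromatic carbon. Going by the values given here, no measured pair exchanges chloro for trifluoromethyl, so the size of this step has no direct precedent; the one known step shows that a substituent at this carbon shifts the number by a modest amount. The step of no change at the digits printed from compound 2 to compound 3 (within the scatter) is therefore expected to stay within the usual scatter, with no clear direction. Compound 3 is estimated at 20 nM, in the range 7 nM to 60 nM.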

Compound 3, half-maximal effective concentration: 3200 nM
Compound 3: the middle estimate sits 160-fold (2.20 log units) below what was measured; the whole stated range lies below it.
By their numbers in this assay, from the lowest: compound 2; then compound 1; then compound 3.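

In this assay this aromatic carbon proves far more selective about its substituent than the chloro step alone suggested, since the exchange of chloro for trifluoromethyl gives a 160-fold higher number from compound 2 to compound 3 (2.20 log units; beyond the scatter) on the shared core. Set against hydrogen at the same carbon, trifluoromethyl also moves the number the opposite way from chloro, with a 36-fold higher number from compound 1 to compound 3 (1.55 log units; beyond the scatter) in this comparison, so merely placing a substituent here does not lower the number. Nothing shown here accounts for how far these two groups part.

The compounds shown leave open where a fluoro, methyl, methoxy or nitrile group at this carbon would fall relative to chloro and trifluoromethyl. They also leave open whether trifluoromethyl would give a similarly large rise on another aromatic carbon of the fused ring.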